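Shortening the alkylamino chain in a thiosemicarbazide series

The compounds below may be only part of what the source reports. "The series", "measured", "known", "first", "only" and "open" are said of these compounds alone.

Measured compounds:
compound 1, `CCn1c(Cn2c(=O)oc3ccc(C)cc32)n[nH]c1=S`, 87.1%
compound 2, `CCCNC(=S)NNC(=O)Cn1c(=O)oc2ccc(C)cc21`, 80.6%

Of the compounds shown here, two sharing one core have been tested in a functional assay on the whole organism with Mus musculus as the target, read by paw edema, with a stated time of 360 min, at a dose of 100 mg/kg by the oral route; a lower number here means a stronger effect, a higher number a weaker effect of the compound at the dose given. Compound 1, `CCn1c(Cn2c(=O)oc3ccc(C)cc32)n[nH]c1=S`, gives 87.1% in this assay. Compound 2, `CCCNC(=S)NNC(=O)Cn1c(=O)oc2ccc(C)cc21`, gives 80.6%. The two numbers lie within the usual scatter of each other, so compound 2 stands together with compound 1 and nothing separates them on the evidence shown.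

The account now turns to compound 3, `CNC(=S)NNC(=O)Cn1c(=O)oc2ccc(C)cc21`, which has not yet been measured in this assay. It differs from compound 2 in one place: hydrogen in place of ethyl on a saturated chain carbon bound to an amide-type nitrogen. The same difference, cut one bond further out, reads propyl to methyl, or propylamino to methylamino.

Among the measured compounds shown here, no step between measured compounds is available, so nothing in the data shows how a change of this kind moves the number. A change confined to a saturated chain carbon on the thiosemicarbazide end is expected to give no step beyond the scatter, in either direction, and the step from compound 2 to compound 3 is estimated as a number 1.4 percentage points higher from compound 2 to compound 3 (within the scatter). For compound 3 the expected value in this assay is 82%, with a range from 70% to 94%.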

Compound 3, a percentage reported as activity, at one dose (the size of the read-out at that dose, not a potency): 85.8%
Beside the measured number, compound 3's estimate is 3.8 percentage points below it; low and high end bracket the measured number.
By their numbers in this assay, from the lowest: compounds 2, 3 and 1 (each within the scatter of the next).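

Going from propylamino to methylamino gives the first step that can be read at this position in this assay, and that step is a number 5.2 percentage points higher from compound 2 to compound 3 (within the scatter). Taking away the ethyl on a saturated chain carbon bound to an amide-type nitrogen, with its 2 carbon atoms, therefore does not separate the two compounds at this dose, and compound 3 stands together with compound 2 on the thiosemicarbazide end. The compounds shown offer no measurement that could explain this result.

As far as these compounds go, the step covers only the span from propylamino to methylamino, so it remains open whether a longer chain such as hexyl, or a phenyl ring or cyclohexyl ring in that place, would give a step beyond the scatter. A primary amine or a carboxylic acid at the end of the chain is equally untested by these compounds, and a single step cannot show whether the shared core would respond in the same way to such groups.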